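Swapping Fluoro for Chloro on Two Related Cores

The source may hold more compounds than are shown below. What is called first, only, known or untested is meant among the compounds shown, and "the series" means these compounds.

Compound 1 `CC(=O)OC1C(CF)OC(n2c(Cl)nc3cc(Cl)c(Cl)cc32)C1OC(C)=O`: 100000 nM
Compound 2 `CC(=O)OC1C(CCl)OC(n2c(Cl)nc3cc(Cl)c(Cl)cc32)C1OC(C)=O`: 90000 nM
Compound 3 `O[C@@H]1[C@@H](CF)OC(n2c(Cl)nc3cc(Cl)c(Cl)cc32)[C@@H]1O`: > 100000 nM

In a functional assay on KB cells (Homo sapiens) for inhibition (on this read-out higher numbers stand for weaker inhibition and lower numbers for stronger inhibition), compound 1 gives 100000 nM and compound 2 gives 90000 nM. The change between them is chloro in place of fluoro on a saturated chain carbon bound to a saturated ring carbon, and it made a step of a 1.1-fold lower number from compound 1 to compound 2 (0.05 log units; within the scatter). Compound 3 carries a different core from compound 1; how the two cores differ is not broken down here. In this assay compound 3 reaches only a limit of the assay, > 100000 nM, as noted in the limit of > 100000 nM in this assay, at which 1 of the 3 values shown sits.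

Compound 4 `O[C@@H]1[C@@H](CCl)OC(n2c(Cl)nc3cc(Cl)c(Cl)cc32)[C@@H]1O` has not yet been measured. It differs from compound 3 by chloro in place of fluoro on a saturated chain carbon bound to a saturated ring carbon, the same change, at the same place, that turned compound 1 into compound 2. Since that step was a 1.1-fold lower number from compound 1 to compound 2 (0.05 log units; within the scatter), compound 4 is expected to move from compound 3 by about a number no higher from compound 3 to compound 4 (the limit leaves the size open). Compound 4 is therefore estimated at 100000 nM, between 40000 nM and 300000 nM, and it may well again reach only a limit.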

Compound 4, half-maximal inhibitory concentration: 90000 nM
Beside the measured number, compound 4's estimate is 1.1-fold (0.05 log units) above it, within the range that was stated.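

In this assay, chloro in place of fluoro gives an at least 1.1-fold lower number from compound 3 to compound 4 (0.04 log units; that floor lies within the scatter). The value of compound 3, > 100000 nM, is a limit of the assay and not an exact number, so this step has only a floor. On both cores, the change shows no step beyond the usual scatter, but the true size of the step on the second core remains unknown, so this does not show that the change carries over with the same effect: the same change on two cores in this assay, a 1.1-fold lower number (0.05 log units; within the scatter) from compound 1 to compound 2 and an at least 1.1-fold lower number (0.04 log units; that floor lies within the scatter) from compound 3 to compound 4; the limit leaves it open whether they differ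

The compounds shown leave open what an amine, a hydroxyl or a bromo in place of the fluoro would do on a saturated chain carbon bound to a saturated ring carbon. They also leave open whether any such group would give a clear step on either core in this assay.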